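The source may hold more compounds than are shown below. What is called first, only, known or untested is meant among the compounds shown, and "the series" means these compounds.

Measured in an ADME assay on MT2 cells (Homo sapiens) for cytotoxicity, read by XTT assay, with a stated time of 4 days; a lower number here means that less compound is tolerated, a higher number that more compound is tolerated:
- compound 1 `Cc1nc2cc(-c3cccc(-c4ccccc4)c3)nn2c(-c2cc(F)c3c(c2C)CCCO3)c1[C@H](OC(C)(C)C)C(=O)O`: 6590 nM
- compound 2 `Cc1ccccc1-c1cccc(-c2cc3nc(C)c([C@H](OC(C)(C)C)C(=O)O)c(-c4cc(F)c5c(c4C)CCCO5)n3n2)c1`: 28200 nM

Compound 2 stands higher of the two. Compound 3 `COc1ccccc1-c1cccc(-c2cc3nc(C)c([C@H](OC(C)(C)C)C(=O)O)c(-c4cc(F)c5c(c4C)CCCO5)n3n2)c1` carries methoxy in place of methyl on an aromatic carbon, ortho to a large group: methoxy in place of methyl on an aromatic carbon. Going by the values given here, only one measured step bears on this, the modest 4.3-fold higher number from compound 1 to compound 2 (0.63 log units; beyond the scatter), which came from methyl in place of hydrogen on an aromatic carbon. One step gives little guidance on a methoxy, so no change beyond the scatter is expected, with a slight drop at most. The expected step is a 1.4-fold lower number from compound 2 to compound 3 (0.15 log units; within the scatter). For compound 3 the estimate is 20000 nM, with an expected range of 9000 nM to 45000 nM.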

Compound 3, half-maximal cytotoxic concentration: 23500 nM
Compound 3: the middle estimate sits 1.2-fold (0.07 log units) below what was measured; low and high end bracket the measured number.
By their numbers in this assay, from the lowest: compound 1; then compounds 3 and 2 (each within the scatter of the next).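

In this assay, methoxy and methyl read alike at this place, ortho to a large group (a 1.2-fold lower number from compound 2 to compound 3 (0.08 log units; within the scatter)). Methoxy in place of hydrogen also gives a step beyond the scatter (a 3.6-fold higher number from compound 1 to compound 3 (0.55 log units; beyond the scatter)), so the higher tolerated concentration seen with methyl is not unique to methyl among the compounds shown. Nothing available explains this result.

Still open, from the compounds shown here alone, is whether a larger ether such as ethoxy, or an amine, at this place would read the same. Also open, going by these compounds, is whether the same swap elsewhere on this ring would do so.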